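From phenyl to methyl on the carbonyl carbon

The compounds below may be only part of what the source reports. "The series", "measured", "known", "first", "only" and "open" are said of these compounds alone.

In an assay on LNCaP cells for inhibition of 3-oxo-5-alpha-steroid 4-dehydrogenase 1 (Homo sapiens) (on this read-out lower numbers stand for stronger inhibition and higher numbers for weaker inhibition), compound 2 `C=CCc1c(OC(=O)c2ccccc2)ccc2ccc(=O)oc12` gives 0.15 ug/mL. Compound 1 `C=CC(C)(C)Oc1ccc2ccc(=O)oc2c1` gives 0.3 ug/mL in this assay, and the two numbers lie within the usual scatter of one another, so neither compound can be called stronger. Compound 3 `C=CCc1c(OC(C)=O)ccc2ccc(=O)oc12` has not yet been measured; it differs from compound 2 in one place: methyl in place of phenyl on a carbonyl carbon. Among the compounds with values here, no measured pair shows this change, so nothing in the numbers tells its effect. The change is expected to shift the result little, a 1.7-fold higher number from compound 2 to compound 3 (0.22 log units; within the scatter) in this assay, staying within the scatter. Compound 3 is therefore estimated at 0.25 ug/mL, with a range from 0.08 ug/mL to 0.8 ug/mL.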

Compound 3, half-maximal inhibitory concentration: 0.2 ug/mL
Compound 3: middle estimate off by 1.3-fold (0.10 log units), on the high side, and the stated range covers the measured number.
By their numbers in this assay, from the lowest: compounds 2, 3 and 1 (each within the scatter of the next).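

Within the data shown here, on the carbonyl carbon, methyl in place of phenyl gives a 1.3-fold higher number from compound 2 to compound 3 (0.12 log units; within the scatter) in this assay, the first measured look at this change. The six-membered aromatic ring at this place is therefore not needed to keep the number in this range, and the read-out does not separate phenyl from methyl. Nothing available explains why the two groups read alike.

Still open, on these data alone, is whether a longer chain or an amine on this carbonyl carbon would read the same. The two groups tested also leave unclear how much variation this place allows.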